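A Phenyl-for-Methyl Swap Tried on a Second Core

The source may report more compounds than this note shows. Statements on the series, on what has been measured and on what is new or still open speak of the compounds shown alone.

Compound 1 `Cc1nn(C)c2c1C(c1ccc(C(F)(F)F)cc1)C(C#N)=C(N)O2` serves as the reference point. In a functional assay on NCI-H2122 cells (Homo sapiens) for inhibition, read by microscopy, with a stated time of 10 days (on this read-out lower numbers stand for stronger inhibition and higher numbers for weaker inhibition), compound 1 gives 2200 nM. Compound 2 `Cn1nc(-c2ccccc2)c2c1OC(N)=C(C#N)C2c1ccc(C(F)(F)F)cc1` differs from compound 1 by a single change, (phenyl in place of methyl on an aromatic carbon). In this assay compound 2 gives 4100 nM, and the step was a 1.9-fold higher number from compound 1 to compound 2 (0.27 log units; within the scatter).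

Compound 3 `Cc1nn(C)c2c1C(c1ccc(OC(F)(F)F)cc1)C(C#N)=C(N)O2` differs from compound 1 in a different place: trifluoromethoxy in place of trifluoromethyl on an aromatic carbon. In this assay compound 3 gives 2900 nM, a step of a 1.3-fold higher number from compound 1 to compound 3 (0.12 log units; within the scatter).

Compound 4 `Cn1nc(-c2ccccc2)c2c1OC(N)=C(C#N)C2c1ccc(OC(F)(F)F)cc1` has not been measured yet. Its difference from compound 3 is phenyl in place of methyl on an aromatic carbon. This is the same change that turned compound 1 into compound 2, now made on the core of compound 3 rather than the core of compound 1; the surroundings of the place are described in exactly the same words in both cases, and the two cores differ only by the trifluoromethoxy-for-trifluoromethyl exchange already described. Nothing is known about how any of these compounds bind, so the expectation can rest only on the measured step. Because the same change gave a 1.9-fold higher number from compound 1 to compound 2 (0.27 log units; within the scatter), the step in this assay from compound 3 to compound 4 is expected to be of a similar size, a 1.9-fold higher number from compound 3 to compound 4 (0.28 log units; within the scatter). Compound 4 is therefore estimated at 5500 nM, with a likely range from 2500 nM to 12000 nM.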

Compound 4, half-maximal inhibitory concentration: 5500 nM
Compound 4: the middle estimate sits on the measured number at the digits printed; the range from low to high includes it.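

In this assay, the phenyl-for-methyl change behaved the same way on the second core as on the first, giving a 1.9-fold higher number from compound 3 to compound 4 (0.28 log units; within the scatter), which matches the earlier step: the same change on two cores in this assay, a 1.9-fold higher number (0.27 log units; within the scatter) from compound 1 to compound 2 and a 1.9-fold higher number (0.28 log units; within the scatter) from compound 3 to compound 4, 1.0-fold (0.01 log units) apart, within the scatter of two such steps

The trifluoromethoxy-for-trifluoromethyl change can also be read on both cores, and with a 1.3-fold higher number from compound 2 to compound 4 (0.13 log units; within the scatter) it agrees with its own earlier step: the same change on two cores in this assay, a 1.3-fold higher number (0.12 log units; within the scatter) from compound 1 to compound 3 and a 1.3-fold higher number (0.13 log units; within the scatter) from compound 2 to compound 4, 1.0-fold (0.01 log units) apart, within the scatter of two such steps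

Within these four compounds, then, each change gave a similar step whichever core carried it, but every one of these steps lies within the scatter of repeated measurements, so the agreement does not show that either change really moves the number, and two cores cannot show that the same would hold on a third.

The compounds shown leave open whether any group on that aromatic carbon other than methyl and phenyl, such as an amine or a longer chain, would give a step that rises clearly above the scatter. As far as these compounds go, it also remains open whether replacing trifluoromethyl or trifluoromethoxy with a carboxylic acid would give a larger step, and whether such a step would carry from one core to the other as these two did.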